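The compounds below may be only part of what the source reports. "The series", "measured", "known", "first", "only" and "open" are said of these compounds alone.

Measured so far:
compound 1, `Nc1ncnc2c1ncn2/C=C/C=O`, > 100000 nM
compound 2, `CC(=O)/C=C/n1cc(C)c(=O)[nH]c1=O`, > 100000 nM
compound 3, `Cc1cn([C@H]2C[C@H](O)[C@@H](CO)O2)c(=O)n(/C=C/C=O)c1=O`, 20000 nM

All three were tested in a functional assay on HeLa cells (Homo sapiens) for inhibition; a lower number here means a stronger inhibitor, a higher number a weaker inhibitor. For compound 1 the result is a limit of the assay and not a number. The same holds for compound 2, whose result is also a limit. Compound 3 is the only one of the three with a measured number, so it stands alone; the other two sit at the limit of > 100000 nM in this assay, at which 2 of the 3 values shown sit, and give no number to compare against.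

Compound 4, `Cc1cn([C@@H]2O[C@H](CO)[C@@H](O)[C@H]2O)c(=O)n(/C=C/C=O)c1=O`, has not yet been measured in this assay. It differs from compound 3 in one place: hydroxy in place of hydrogen on a saturated ring carbon. This is a small addition on a saturated ring carbon, away from the part of the structure that the three measured compounds share in various forms.

Among the measured compounds shown here, since no step between two measured compounds is available, the size of this change can only be guessed. The step from compound 3 to compound 4 is expected to be small, a 1.5-fold higher number from compound 3 to compound 4 (0.18 log units; within the scatter), not clearly beyond the scatter in either direction. Compound 4 is therefore estimated at 30000 nM, within a range from 8000 nM to 100000 nM.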

Compound 4, half-maximal inhibitory concentration: 100000 nM
Beside the measured number, compound 4's estimate is 3.3-fold (0.52 log units) below it; the measured number falls inside the stated range.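

In this assay, the change from hydrogen to hydroxy on this saturated ring carbon gives a 5.0-fold higher number from compound 3 to compound 4 (0.70 log units; beyond the scatter) and so makes a weaker inhibitor. Among the compounds shown here, this is the first comparison here between two compounds that differ in one place, and it shows that this ring carbon does not tolerate every change without a shift in the number. Compound 1 and compound 2 cannot add to this comparison, as the result for each is a limit of the assay and not a number: the limit of > 100000 nM in this assay, at which 2 of the 4 values shown sit.

From the compounds shown here alone, only hydrogen and hydroxy are compared on this carbon, so it remains open what an amine, a methoxy group or a fluorine atom there would do. Going by these compounds, it is also open whether the hydroxy step would be the same size with a different side chain on the shared core.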